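A Benzyl Group Replaces the Methoxyphenyl of Compound 2

The compounds below may be only part of what the source reports. "The series", "measured", "known", "first", "only" and "open" are said of these compounds alone.

Going by the values given here, compound 2 `COc1ccc(-n2cc(CNC(=O)c3cccc4c3cnn4C(C)C)nn2)cc1` is the one compound here that gives a number in a functional assay on PC-3 cells (Homo sapiens) for inhibition, read by MTT assay, with a stated time of 72 h; a lower number here means a stronger inhibitor, a higher number a weaker inhibitor: in this assay compound 2 reaches 34300 nM. Compound 1 `CC(C)n1ncc2c(C(=O)NCc3cn(-c4ccc(F)cc4)nn3)cccc21` shows only a limit, > 40000 nM, in this assay (the limit of > 40000 nM in this assay, at which 1 of the 2 values shown sits). Among the compounds with values here, the single measured step, an at least 1.1-fold lower number from compound 1 to compound 2 (0.06 log units; that floor lies within the scatter), changes fluoro to methoxy on the aromatic carbon and stays within the scatter, so it says little about direction.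

Compound 3 `CC(C)n1ncc2c(C(=O)NCc3cn(Cc4ccccc4)nn3)cccc21` carries benzyl in place of 4-methoxyphenyl on an aromatic nitrogen. Within the data shown here, no measured step touches this kind of change, in which the aromatic group gives way to benzyl and the methoxy acceptor is lost. Among the measured compounds shown here, the only step on record, an at least 1.1-fold lower number from compound 1 to compound 2 (0.06 log units; that floor lies within the scatter), is flat, and compound 2 already sits close to the limit at which compound 1 stands. Compound 3 is therefore expected to show a 1.2-fold higher number from compound 2 to compound 3 (0.07 log units; within the scatter), that is no step beyond the scatter. Compound 3 is estimated at 40000 nM, with a range from 15000 nM to 100000 nM.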

Compound 3, half-maximal inhibitory concentration: 4420 nM
Compound 3: the middle estimate sits 9.0-fold (0.96 log units) above what was measured; the measured number lies below the stated range.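

Going by these compounds alone, at the aromatic nitrogen of the five-membered ring, the earlier compounds showed only a change on the aromatic ring that stayed within the scatter, whereas benzyl in place of 4-methoxyphenyl moves the number beyond the scatter in this assay, with a 7.8-fold lower number from compound 2 to compound 3 (0.89 log units; beyond the scatter). Benzyl in place of 4-fluorophenyl points the same way, with an at least 9.0-fold lower number from compound 1 to compound 3 (0.95 log units; beyond the scatter). That step is only a floor, since compound 1 gives a limit of the assay and not a number: the limit of > 40000 nM in this assay, at which 1 of the 3 values shown sits.

The compounds shown leave open whether a longer chain on this nitrogen, such as phenethyl, would lower the number further than benzyl does. They also leave open how a cyclohexylmethyl group, a chain ending in an amine, or a methoxy or fluoro group on the benzyl ring would read in this assay.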